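This account rests on a few compounds, and the source may have more. Where it says the series, first, only, none or still open, it means among the compounds named here.

Measured compounds:
compound 1 `O=C(CN1CCN(S(=O)(=O)c2ccccc2F)CC1)Nc1ccccc1F` gives 8000 nM in an in vitro assay on HEK ts201 cells for negative allosteric modulation of Neuronal acetylcholine receptor; alpha4/beta2 (Homo sapiens), read by fluorescence and calcium flux, with a stated time of 1.5 s; a higher number here means a weaker inhibitor, a lower number a stronger inhibitor
compound 2 `O=C(CN1CCN(S(=O)(=O)c2ccccc2F)CC1)Nc1ccc(F)cc1` gives 8000 nM in this assay
compound 3 `COc1ccc(NC(=O)CN2CCN(S(=O)(=O)c3ccccc3F)CC2)cc1` gives 17100 nM in this assay

Compound 3 has the highest number of the three, so it is the weakest inhibitor here: its step from compound 1 reads a 2.1-fold higher number from compound 1 to compound 3 (0.33 log units; beyond the scatter), and from compound 2 it reads a 2.1-fold higher number from compound 2 to compound 3 (0.33 log units; beyond the scatter), both beyond the scatter, while compound 1 and compound 2 sit within the scatter of each other, no change at the digits printed from compound 1 to compound 2 (within the scatter).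

Compound 4 `COC(=O)c1ccc(NC(=O)CN2CCN(S(=O)(=O)c3ccccc3F)CC2)cc1` is not yet measured. It differs from compound 3 in one place: methoxycarbonyl in place of methoxy on an aromatic carbon. For the measured compounds named here, the step that bears most directly on this is the one from compound 2 to compound 3, where a methoxy took the place of a fluoro on the same aromatic carbon and the number rose modestly. Going by the values given here, a further exchange at that carbon, now to methoxycarbonyl, has no measured precedent in this set, so the direction is uncertain; a modest step in either direction, or none beyond the scatter, would fit what is known. Compound 4 is therefore expected to give about 20000 nM in this assay, within a range of 7000 nM to 55000 nM, which means an estimated step of a 1.2-fold higher number from compound 3 to compound 4 (0.07 log units; within the scatter) from compound 3.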

Compound 4, half-maximal inhibitory concentration: 12400 nM
Beside the measured number, compound 4's estimate is 1.6-fold (0.21 log units) above it, and the stated range covers the measured number.
By their numbers in this assay, from the lowest: compounds 1, 2, 4 and 3 (each within the scatter of the next, the first and the last beyond it).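

In this assay, methoxycarbonyl in place of methoxy on this aromatic carbon gives a 1.4-fold lower number from compound 3 to compound 4 (0.14 log units; within the scatter) even though the group brings more heavy atoms, a double bond and an extra hydrogen-bond acceptor. Compound 4 also gives a 1.6-fold higher number from compound 2 to compound 4 (0.19 log units; within the scatter) and a 1.6-fold higher number from compound 1 to compound 4 (0.19 log units; within the scatter) when set against the fluorinated compounds. Methoxy and fluoro at this carbon had stood just beyond the scatter of each other, but compound 4 lies within the scatter of all three earlier compounds, so a larger group with a carbonyl here produces no clear shift.

As far as these compounds go, whether an amine, a carboxylic acid or a longer chain on this carbon would move the number beyond the scatter remains open. No measurement available here explains these small differences.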